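This account rests on a few compounds, and the source may have more. Where it says the series, first, only, none or still open, it means among the compounds named here.

In a functional assay on NCI/ADR-RES cells (Homo sapiens) for positive allosteric modulation, read by MTT assay, with a stated time of 48 h, tested at 10 uM (a lower number here means a stronger inhibitor, a higher number a weaker inhibitor), compound 1 `C=C1[C@H](OCC(C)C)C2=C(C[C@@](C)(OC(C)=O)[C@@H]2OC(C)=O)[C@@H](OC(=O)c2ccccc2)[C@@H](C)/C=C/C(C)(C)[C@H](OC(C)=O)[C@H](OC(C)=O)[C@H]1OCC(C)C` gives 3700 nM. Compound 2 `C=C1[C@H](O)[C@@H](O)[C@@H](O)C(C)(C)/C=C/[C@H](C)[C@H](OC(=O)c2ccccc2)[C@@]2(O)C[C@@](C)(O)[C@H](OC(C)=O)[C@@H]2[C@H]1OCC(C)C` gives > 100000 nM, and this is a limit of the assay, not a number. Compound 3 `CC(=O)O[C@@H]1[C@@H]2[C@@H](OCC(C)C)C3(CO3)[C@H](O)[C@@H](O)[C@@H](O)C(C)(C)/C=C/[C@H](C)[C@H](OC(=O)c3ccccc3)[C@@]2(O)C[C@@]1(C)O` gives > 100000 nM, which is likewise a limit. The position of compound 2 is therefore known only as a limit: the limit of > 100000 nM in this assay, at which 2 of the 3 values shown sit.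

Compound 4 `C=C1[C@H](O)[C@@H](OC(=O)c2cccc(C)c2)[C@@H](O)C(C)(C)/C=C/[C@H](C)[C@H](OC(=O)c2ccccc2)[C@@]2(O)C[C@@](C)(O)[C@H](OC(C)=O)[C@@H]2[C@H]1OCC(C)C` differs from compound 2 in one place: (3-methylphenyl)carbonyl in place of hydrogen on an oxygen on a saturated carbon. In words, (3-methylphenyl)carbonyl stands in place of hydrogen on an oxygen on a saturated carbon, so a hydroxy group becomes ((3-methylphenyl)carbonyl)oxy.

Going by the values given here, no two measured compounds differ in just one place, so no measured step gives the size of this change. Among the compounds with values here, the only firm guide is compound 1 at 3700 nM, which shows that a true number can be obtained in this assay for a compound of this series. A sizeable step towards stronger inhibition is expected, though compound 4 may also end up at the limit. The expected change is an at least 5.0-fold lower number from compound 2 to compound 4 (0.69 log units; beyond the scatter), and this estimate is rough since its starting point is a limit. For compound 4, the estimated value is 20000 nM, with an expected range from 5000 nM to 80000 nM.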

Compound 4, half-maximal inhibitory concentration: 7640 nM
Estimate against measurement, compound 4: 2.6-fold (0.42 log units) above; the measured number falls inside the stated range.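

this assay compound 2 gives > 100000 nM, which is a limit of the assay and not a number. Turning one of its hydroxy groups into ((3-methylphenyl)carbonyl)oxy gives an at least 13-fold lower number from compound 2 to compound 4 (1.11 log units; beyond the scatter), so this oxygen on a saturated carbon is a place where a single change can lift a compound from the limit to a true number. The full size of the step cannot be given, since it starts from a limit and only its lower bound is known: the limit of > 100000 nM in this assay, at which 2 of the 4 values shown sit.

The compounds shown leave open how much of this step rests on the aromatic ring, its methyl group or the carbonyl, a question that a plain benzoyl or an acetyl group on the same oxygen would help to answer. Going by these compounds, it also remains open whether a longer alkyl chain or an amine-bearing acyl group would be tolerated here, and whether the same (3-methylphenyl)carbonyl group would have a similar effect on the other hydroxy groups of compound 2.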